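Cytotoxicity notes: from compound 2 to compound 3

The source may hold more compounds than are shown below. What is called first, only, known or untested is meant among the compounds shown, and "the series" means these compounds.

In a toxicity assay on HEK-293T cells (Homo sapiens) for cytotoxicity, read by MTT assay, with a stated time of 72 h (a lower number here means a stronger inhibitor, a higher number a weaker inhibitor), compound 1 (`O=C1c2c[n+]([O-])c3ccccc3c2C(=O)c2c1c1ccccc1n2CCCCN1CCNCC1`) gives 760 nM and compound 2 (`O=C1c2c[n+]([O-])c3ccccc3c2C(=O)c2c1c1ccccc1n2Cc1cn([C@H]2C[C@H](O)[C@@H](CO)O2)nn1`) gives 3600 nM as the higher of the two numbers, a gap beyond the usual scatter. Compound 2 is therefore the weaker inhibitor of this pair.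

Compound 3 (`O=C1c2c[n+]([O-])c3ccccc3c2C(=O)c2c1c1ccccc1n2Cc1cn(C[C@@H](O)CO)nn1`) has not yet been measured. It carries 2,3-dihydroxypropyl in place of 4-hydroxy-5-(hydroxymethyl)oxolan-2-yl on an aromatic nitrogen. Going by the values given here, no measured step covers this exchange. The expectation therefore starts from compound 2 at 3600 nM and assumes no change beyond the scatter, with no firm direction. The expected size is a 1.2-fold lower number from compound 2 to compound 3 (0.08 log units; within the scatter) as a working figure. For compound 3 the estimate is 3000 nM with an expected range from 1000 nM to 9000 nM in this assay once measured.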

Compound 3, half-maximal inhibitory concentration: 2030 nM
Compound 3: the middle estimate sits 1.5-fold (0.17 log units) above what was measured; measured number inside the range.
By their numbers in this assay, from the lowest: compound 1; then compounds 3 and 2 (each within the scatter of the next).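

In this assay, 2,3-dihydroxypropyl in place of 4-hydroxy-5-(hydroxymethyl)oxolan-2-yl on the aromatic nitrogen gives a 1.8-fold lower number from compound 2 to compound 3 (0.25 log units; within the scatter), so at this position the ring and the additional defined stereocentres can be exchanged with a step that stays within the scatter. With 1-(2,3-dihydroxypropyl)-1H-1,2,3-triazol-4-yl in place of 3-(piperazin-1-yl)propyl, the series shows a 2.7-fold higher number from compound 1 to compound 3 (0.43 log units; beyond the scatter), so a gap beyond the scatter from compound 1 does not require the 4-hydroxy-5-(hydroxymethyl)oxolan-2-yl ring. No measurement at hand gives a reason for either step.

The compounds shown leave open which part of the second exchange carries that gap, the piperazin-1-yl group or the triazole with its substituent. Also open, as far as these compounds go, is how a 2-aminoethyl group in place of 2,3-dihydroxypropyl on that aromatic nitrogen would read in this assay.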